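From 2-methylbenzyl to 4-methylbenzyl: notes on compound 4

A few compounds are considered here, and "the series" means these few. Any claim that something is new, unique, unknown or untested is made for them only; others in the source may bear on it.

- compound 1 `O=[N+]([O-])c1cccc(CSc2nnc(-c3ccc4c(c3)OCCO4)o2)c1`: 38300 nM
- compound 2 `Cc1ccccc1CSc1nnc(-c2ccc3c(c2)OCCO3)o1`: 22000 nM
- compound 3 `O=[N+]([O-])c1ccccc1CSc1nnc(-c2ccc3c(c2)OCCO3)o1`: 38100 nM

In a functional assay on HepG2 cells (Homo sapiens) for antiproliferative activity, read by MTT assay, with a stated time of 48 h (a lower number here means a stronger inhibitor, a higher number a weaker inhibitor), compound 2 gives 22000 nM, within the scatter of both other compounds, so it holds no clear place among them. Compound 4 `Cc1ccc(CSc2nnc(-c3ccc4c(c3)OCCO4)o2)cc1` has the same atoms as compound 2, joined differently: 4-methylphenyl in place of 2-methylphenyl on a saturated chain carbon bound to a sulfur. Among the compounds with values here, the one measured step, a 1.7-fold higher number from compound 2 to compound 3 (0.24 log units; within the scatter), replaces methyl with nitro, lies within the scatter and does not test a shift of the methyl group. Within the data shown here, no measured compound carries 4-methylphenyl, so no step beyond the scatter is expected in this assay. The expected change is a 1.1-fold higher number from compound 2 to compound 4 (0.06 log units; within the scatter). For compound 4 the estimate is 25000 nM, with an expected range of 11000 nM to 50000 nM.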

Compound 4, half-maximal inhibitory concentration: 41900 nM
The estimate for compound 4 lay 1.7-fold (0.22 log units) below the measured number; the range from low to high includes it.
By their numbers in this assay, from the lowest: compounds 2, 3, 1 and 4 (each within the scatter of the next).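

The shift from 2-methylphenyl to 4-methylphenyl on a saturated chain carbon bound to a sulfur now has a direct reading: in this assay it gives a 1.9-fold higher number from compound 2 to compound 4 (0.28 log units; within the scatter) and does not separate the two methyl placements. Earlier compounds tested only the replacement of methyl with nitro, not a move of the methyl group. Nothing available explains this small step.

Still open, as far as these compounds go, is whether an amine or a carboxylic acid in place of methyl on the benzyl group would give a step beyond the scatter. A longer chain between the sulfur and the aromatic ring also remains untested in the compounds shown here.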